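The compounds below may be only part of what the source reports. "The series", "measured", "known", "first", "only" and "open" are said of these compounds alone.

Compound 2 `Cc1cc(Nc2nc(Nc3ccc(C(=O)NC4CC(C)(C)N([O])C(C)(C)C4)cc3)ncc2[N+](=O)[O-])n[nH]1` and compound 1 `CC1(C)CC(NC(=O)c2ccc(Nc3ncc([N+](=O)[O-])c(NC4CCCC4)n3)cc2)CC(C)(C)N1[O]` share one core and differ only in the group attached to a nitrogen on an aromatic ring. In a functional assay on HepG2 cells (Homo sapiens) for antiproliferative activity, read by MTT assay, with a stated time of 48 h (a higher number here means a weaker inhibitor, a lower number a stronger inhibitor), compound 1 gives 28700 nM, and compound 2 gives 37500 nM; the two numbers sit within the usual scatter of each other, so neither compound can be called the weaker of the pair. Among the measured compounds shown here, the only measured step at this position, a 1.3-fold higher number from compound 1 to compound 2 (0.12 log units; within the scatter), thus shows that swapping a cyclopentyl for a 5-methyl-1H-pyrazol-3-yl changed nothing that can be trusted.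

Compound 3 `CCOC(=O)c1csc(Nc2nc(Nc3ccc(C(=O)NC4CC(C)(C)N([O])C(C)(C)C4)cc3)ncc2[N+](=O)[O-])n1` is made from compound 2 by the change (4-(ethoxycarbonyl)-1,3-thiazol-2-yl in place of 5-methyl-1H-pyrazol-3-yl on a nitrogen on an aromatic ring). For the measured compounds named here, only the step from compound 1 to compound 2 bears on this position, and it was within the scatter; the new group is larger and carries no hydrogen-bond donor, but nothing measured here tells how that matters. The expectation is therefore a step of about a 1.1-fold lower number from compound 2 to compound 3 (0.03 log units; within the scatter) in this assay, that is, no change beyond the scatter. Compound 3 is estimated at 35000 nM, with a range from 12000 nM to 100000 nM.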

Compound 3, half-maximal inhibitory concentration: 6870 nM
For compound 3 the middle estimate is 5.1-fold (0.71 log units) above the measured one; the whole stated range lies above it.
By their numbers in this assay, from the lowest: compound 3; then compounds 1 and 2 (each within the scatter of the next).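

In this assay, this position turns out to respond to the group placed on the nitrogen: 4-(ethoxycarbonyl)-1,3-thiazol-2-yl in place of 5-methyl-1H-pyrazol-3-yl gives a 5.5-fold lower number from compound 2 to compound 3 (0.74 log units; beyond the scatter) in this series, and in place of cyclopentyl it gives a 4.2-fold lower number from compound 1 to compound 3 (0.62 log units; beyond the scatter) as well. Among the compounds shown here, the earlier pair showed no difference that could be trusted, so compound 3 is the first sign that a change at this position can move the number, and both of its steps lie beyond the scatter, which places it lowest of the three. Nothing available here says why the number fell.

The compounds shown leave open whether the step belongs to the five-membered ring that enters or to the ethoxycarbonyl group it carries, as the two arrive together in a single change. A plain 1,3-thiazol-2-yl with no ester, or a carboxylic acid or a primary amide in place of the ethyl ester, would pull these two parts apart and show which of them goes with the lower number.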